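Shifting a Hydroxyl Group on a Benzylamide Side Chain

The source may hold more compounds than are shown below. What is called first, only, known or untested is meant among the compounds shown, and "the series" means these compounds.

Measured so far:
compound 1 `Cc1cc(C)cc(S(=O)(=O)c2c(C(=O)Nc3ccc(O)cc3)[nH]c3ccc(Cl)cc23)c1`: 18100 nM
compound 2 `Cc1cc(C)cc(S(=O)(=O)c2c(C(=O)NCc3cccc(O)c3)[nH]c3ccc(Cl)cc23)c1`: 27000 nM

Going by the values given here, in an ADME assay on MT4 cells (Homo sapiens) for cytotoxicity, read by MTT assay (a lower number here means that less compound is tolerated, a higher number that more compound is tolerated), compound 2 holds the higher of the two numbers, yet the only step known, a 1.5-fold higher number from compound 1 to compound 2 (0.17 log units; within the scatter), lies within the scatter, so the two compounds cannot be told apart. Compound 3 `Cc1cc(C)cc(S(=O)(=O)c2c(C(=O)NCc3ccc(O)cc3)[nH]c3ccc(Cl)cc23)c1` differs from compound 2 by 4-hydroxyphenyl in place of 3-hydroxyphenyl on a saturated chain carbon bound to an amide-type nitrogen. Among the compounds with values here, the one measured step changed both the hydroxyl placement and the linker without a clear effect, so no step beyond the scatter is expected here. Compound 3 is expected at 25000 nM, with a range from 12000 nM to 50000 nM. This corresponds to an expected step of a 1.1-fold lower number from compound 2 to compound 3 (0.03 log units; within the scatter).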

Compound 3, half-maximal cytotoxic concentration: 6250 nM
The estimate for compound 3 lay 4.0-fold (0.60 log units) above the measured number; measured number outside the range, below it.
By their numbers in this assay, from the lowest: compound 3; then compounds 1 and 2 (each within the scatter of the next).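

In this assay the place of the hydroxyl does matter on this side chain: 4-hydroxybenzyl in place of 3-hydroxybenzyl gives a 4.3-fold lower number from compound 2 to compound 3 (0.64 log units; beyond the scatter) and so less compound is tolerated. The saturated chain carbon matters too when the hydroxyl stays in the 4-hydroxy form, with a 2.9-fold lower number from compound 1 to compound 3 (0.46 log units; beyond the scatter) as the result, something the earlier pair, which changed both features at once, could not show. Nothing available explains either difference. On these data alone, whether an amine or a methoxy group in place of that hydroxyl, or a longer chain such as 4-hydroxyphenethyl, would move the number remains open.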